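The source may report more compounds than this note shows. Statements on the series, on what has been measured and on what is new or still open speak of the compounds shown alone.

In an assay on isolated protein for displacement of a labelled ligand from metabotropic glutamate receptor 5 (Homo sapiens), with a stated time of 60 min, tested at 1 uM (on this read-out higher numbers stand for more inhibition at the one concentration tested (going by the name of the read-out) and lower numbers for less inhibition), three compounds sharing one core have been measured so far. Compound 1 `Cc1ccc2ncc(S(=O)(=O)c3ccc(Cl)c(Cl)c3)c(N3CCC(C)CC3)c2c1` gives 82%, compound 2 `Cc1ccc2ncc(S(=O)(=O)c3cc(F)cc(F)c3)c(N3CCC(C)CC3)c2c1` gives 72%, and compound 3 `Cc1ccc2ncc(S(=O)(=O)c3ccc(C)c(Cl)c3)c(N3CCC(C)CC3)c2c1` gives 91%. On these numbers compound 3 stands highest of the three: its nearest neighbour is compound 1, within the scatter, and its furthest is compound 2, beyond the scatter.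

The next compound, compound 4 `Cc1ccc2ncc(S(=O)(=O)c3cccc(F)c3)c(N3CCC(C)CC3)c2c1`, is not yet measured. It differs from compound 3 in one place: 3-fluorophenyl in place of 3-chloro-4-methylphenyl on a sulfonyl sulfur.

Going by the values given here, two measured steps bear on this change. The step of a number 19 percentage points higher from compound 2 to compound 3 (beyond the scatter) shows that exchanging a fluorinated phenyl on the sulfonyl sulfur for 3-chloro-4-methylphenyl raised the number by a modest but real amount, and the step of a number 10 percentage points lower from compound 1 to compound 2 (within the scatter) shows that a move from 3,4-dichlorophenyl to 3,5-difluorophenyl lowered it, though only within the scatter. The step of a number 9 percentage points higher from compound 1 to compound 3 (within the scatter) also lies within the scatter. Among the compounds with values here, the change now considered runs the opposite way to the one real step, from a chloro-methyl-bearing phenyl back to a fluorinated one, so a modest decrease in this assay is expected rather than no change. The step expected is a number 21 percentage points lower from compound 3 to compound 4 (beyond the scatter). For compound 4 the estimate is 70%, with a range from 55% to 85%.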

Compound 4, a percentage reported as inhibition, at one concentration (the size of the read-out at that concentration, not a potency): 94%
Estimate against measurement, compound 4: 24 percentage points below, outside the stated range (above it).
By their numbers in this assay, from the lowest: compounds 2, 1, 3 and 4 (each within the scatter of the next, the first and the last beyond it).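

In this assay, a number 3 percentage points higher from compound 3 to compound 4 (within the scatter) shows that no change can be read on replacing 3-chloro-4-methylphenyl with 3-fluorophenyl on a sulfonyl sulfur, so the chloro and methyl groups of compound 3 are not needed for a high number among these compounds. Going by these compounds alone, the a number 22 percentage points higher from compound 2 to compound 4 (beyond the scatter), with hydrogen in place of fluoro on an aromatic carbon, and a number 12 percentage points higher from compound 1 to compound 4 (beyond the scatter), with 3-fluorophenyl in place of 3,4-dichlorophenyl, place the ring with the single fluoro group beyond the scatter above both rings that carry two halogens; thus fluoro on this ring does not by itself go with a lower number, and a second substituent does not by itself go with a higher one, although compound 3, with its chloro and methyl groups, goes against any simple rule that fewer substituents give more inhibition. Nothing available here gives a reason for these differences.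

The compounds shown leave open how an unsubstituted phenyl, or a ring bearing a methoxy group or a nitrile, would behave at this position. With a single tested concentration, they also leave open whether compound 3 and compound 4 would differ in potency.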